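Swapping Fluoro for Methyl on a Urea Series

A few compounds are considered here, and "the series" means these few. Any claim that something is new, unique, unknown or untested is made for them only; others in the source may bear on it.

Three compounds share one core and differ only in the outer ring of the urea. Compound 1 `O=C(Nc1cccc(CNc2nccnc2Cl)c1)Nc1ccc(F)c(Cl)c1` is tested in a functional assay on T-24 cells (Homo sapiens) for antiproliferative activity, read by MTT assay, with a stated time of 48 h (on this read-out lower numbers stand for stronger inhibition and higher numbers for weaker inhibition), and gives 4990 nM. Compound 2 `O=C(Nc1ccc(C(F)(F)F)cc1)Nc1cccc(CNc2nccnc2Cl)c1` gives 4580 nM in the same assay, a number within the scatter of compound 1, so the two cannot be told apart. Compound 3 `CS(=O)(=O)c1ccc(NC(=O)Nc2cccc(CNc3nccnc3Cl)c2)cc1` gives 29300 nM, the highest of the three; compound 1 thus stands second highest, with compound 3 the furthest from it. Among the compounds with values here, the only single change measured so far is a 6.4-fold higher number from compound 2 to compound 3 (0.81 log units; beyond the scatter), a change at a different place than the one now followed.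

Compound 4 `Cc1ccc(NC(=O)Nc2cccc(CNc3nccnc3Cl)c2)cc1Cl` differs from compound 1 by methyl in place of fluoro on an aromatic carbon. Within the data shown here, no measured step concerns this exchange, and the one step that exists does not carry over to it. With nothing pointing in either direction, the number for compound 4 in this assay is expected to sit close to that of compound 1, a step of a 1.1-fold lower number from compound 1 to compound 4 (0.04 log units; within the scatter), not beyond the scatter. The estimate for compound 4 is therefore 4500 nM, with a range from 1500 nM to 14000 nM.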

Compound 4, half-maximal inhibitory concentration: 7390 nM
The estimate for compound 4 lay 1.6-fold (0.22 log units) below the measured number; measured number inside the range.
By their numbers in this assay, from the lowest: compounds 2, 1 and 4 (each within the scatter of the next); then compound 3.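

Replacing fluoro with methyl on the outer ring, on the carbon ortho to the chloro group, gives a 1.5-fold higher number from compound 1 to compound 4 (0.17 log units; within the scatter) in this assay. The earlier compounds shown here held no single step at this exchange, and this first one shows that, with the chloro group kept, the read-out does not separate a fluoro from a methyl at this place. Nothing measured here accounts for the two groups reading alike.

Among the compounds shown with the chloro group present, only fluoro and methyl occupy this place, so how an amine, a hydroxyl or a longer chain such as propyl would read there remains open. Also open, as far as these compounds go, is whether fluoro and methyl would still read alike on an outer ring without the chloro group.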